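From isopropoxy to (methylsulfonyl)oxy on a shared core

A few compounds are considered here, and "the series" means these few. Any claim that something is new, unique, unknown or untested is made for them only; others in the source may bear on it.

Among the measured compounds shown here, in a functional assay on KB cells (Homo sapiens) for cytotoxicity (a higher number here means that more compound is needed for the effect, a lower number that less compound is needed), compound 1 (`CC(C)Oc1cc(-c2ccccc2)nc2ccccc12`) gives 4.2 ug/mL and this is the only actual number so far. Compound 2 (`Oc1cc(-c2ccccc2)nc2cc(F)ccc12`) has a reported limit of < 0.1 ug/mL and this is not a number. For the measured compounds named here, compound 2 also differs from compound 1 in more than one place, so the pair provides no measured step for the change considered here.

Compound 3 (`CS(=O)(=O)Oc1cc(-c2ccccc2)nc2ccccc12`) keeps the core of compound 1 and carries methylsulfonyl in place of isopropyl on an oxygen on an aromatic ring. Going by the values given here, no measured step covers this replacement, so the estimate is anchored on compound 1 at 4.2 ug/mL and stays wide. The expected size of a 1.4-fold lower number from compound 1 to compound 3 (0.15 log units; within the scatter) lies within the usual scatter of this assay with no firm direction expected. For compound 3 the expected value is 3 ug/mL with an estimated range from 0.7 ug/mL to 12 ug/mL as the working figures.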

Compound 3, half-maximal effective concentration: 2.8 ug/mL
For compound 3 the middle estimate is 1.1-fold (0.03 log units) above the measured one; the measured number falls inside the stated range.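

With compound 3 the series gains its first readable step at this position: in this assay, methylsulfonyl in place of isopropyl on an oxygen on an aromatic ring gives a 1.5-fold lower number from compound 1 to compound 3 (0.18 log units; within the scatter). On the shared core, this read-out therefore does not separate isopropoxy from (methylsulfonyl)oxy, even though the two groups differ in make-up: methylsulfonyl brings sulfur, double bonds outside aromatic rings and hydrogen-bond acceptors, none of which isopropyl has. Compound 2 is reported only as a limit, not a number, and it enters no step: the limit of < 0.1 ug/mL in this assay, at which 1 of the 3 values shown sits.

Among the compounds shown here, compound 2 differs from compound 1 in more than one place, so no step through it can be read, and the contribution of the hydroxyl at this position stays unassigned. Also open, going by these compounds, is whether the same flat reading holds for other groups on this oxygen, such as a longer alkyl chain or a chain ending in an amine or a carboxylic acid, and whether it persists on a core carrying a further substituent.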